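The compounds below may be only part of what the source reports. "The series", "measured", "known", "first", "only" and "open" are said of these compounds alone.

Compound 1 `CC(C)c1n[nH]c2c(NCc3ccc(-c4ccccn4)cc3)nc(SCC(C)(C)O)nc12`, compound 2 `CC(C)c1n[nH]c2c(NCc3ccc(-c4ccccn4)cc3)nc(SCCCO)nc12` and compound 3 `CC(C)c1n[nH]c2c(NCc3ccc(-c4ccccn4)cc3)nc(SC3CCCC3O)nc12` share one core and differ only in the group on the sulfur. In a functional assay on HT cells (Homo sapiens) for antiproliferative activity, read by fluorescence, with a stated time of 72 h (on this read-out lower numbers stand for stronger inhibition of growth and higher numbers for weaker inhibition of growth), compound 3 gives 567 nM. Compound 1 gives 507 nM, which lies within the scatter of compound 3, while compound 2 gives a clearly lower 109 nM.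

Compound 4 `CC(C)c1n[nH]c2c(NCc3ccc(-c4ccccn4)cc3)nc(SCCC(N)=O)nc12` is the next structure, and it carries 2-carbamoylethyl in place of 2-hydroxycyclopentyl on a sulfur. This puts 2-carbamoylethyl in place of 2-hydroxycyclopentyl on a sulfur, so the one five-membered non-aromatic ring of carbon only gives way to a group with no ring.

The closest guide is the change from 3-hydroxypropyl, also without a ring, to 2-hydroxycyclopentyl, which gave a 5.2-fold higher number from compound 2 to compound 3 (0.72 log units; beyond the scatter). The swap from 2-hydroxy-2-methylpropyl to 2-hydroxycyclopentyl gave only a 1.1-fold higher number from compound 1 to compound 3 (0.05 log units; within the scatter), and a 4.7-fold lower number from compound 1 to compound 2 (0.67 log units; beyond the scatter) shows that the choice of open chain can also matter. For the measured compounds named here, no measured compound carries an amide, so only part of the step to compound 3 should be recovered in reverse. In this assay the expected change is a 2.8-fold lower number from compound 3 to compound 4 (0.45 log units; beyond the scatter), a lower number but a smaller step than the one seen with the 3-hydroxypropyl group. For compound 4 the estimate is 200 nM, with an expected range from 70 nM to 600 nM.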

Compound 4, concentration for 50% growth inhibition: 120 nM
Compound 4: the middle estimate sits 1.7-fold (0.22 log units) above what was measured, and the stated range covers the measured number.
By their numbers in this assay, from the lowest: compounds 2 and 4 (each within the scatter of the next); then compounds 1 and 3 (each within the scatter of the next).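

In this assay, swapping hydroxymethyl for carbamoyl gives a 1.1-fold higher number from compound 2 to compound 4 (0.04 log units; within the scatter), so among these compounds a hydroxyl group on the sulfur substituent is not required for the lower number, and a primary amide can stand in its place. The other two steps, a 4.7-fold lower number from compound 3 to compound 4 (0.67 log units; beyond the scatter) and a 4.2-fold lower number from compound 1 to compound 4 (0.63 log units; beyond the scatter), add a second open chain to the low end of the series: both unbranched chains, 3-hydroxypropyl and 2-carbamoylethyl, now give lower numbers than the branched 2-hydroxy-2-methylpropyl and the ring-bearing 2-hydroxycyclopentyl, though four compounds can only hint at this pattern. Nothing shown explains why these groups differ in this way.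

The compounds shown leave open how a carboxylic acid, an amine or a longer chain on the sulfur would compare with 2-carbamoylethyl, and whether a branch or ring on a chain bearing the amide would raise the number as it does among the hydroxyl compounds. Because all four results come from one cell read-out, they also leave open whether the same order would hold in any other test.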